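Amide swap on the shared core: chlorophenyl to furan

The compounds below may be only part of what the source reports. "The series", "measured", "known", "first", "only" and "open" are said of these compounds alone.

Measured so far:
Compound 1 `CCOC(=O)c1sc(-c2cccc(NC(=O)c3ccco3)c2)nc1Nc1ccc(N2CCN(C)CC2)cc1`: 15100 nM
Compound 2 `CN1CCN(c2ccc(Nc3nc(-c4cccc(NC(=O)c5ccc(Cl)cc5)c4)sc3C(N)=O)cc2)CC1`: 5700 nM

Of the compounds shown here, two have been tested in a functional assay on Raji cells (Homo sapiens) for antiproliferative activity, read by CCK-8 assay, with a stated time of 72 h; a higher number here means a weaker inhibitor, a lower number a stronger inhibitor. Compound 1 gives 15100 nM in this assay, and compound 2 gives 5700 nM, the lower of the two numbers and a gap that goes beyond the usual scatter. Going by the values given here, the two structures differ in more than one place, so no single step between them can be read.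

Compound 3 `CN1CCN(c2ccc(Nc3nc(-c4cccc(NC(=O)c5ccco5)c4)sc3C(N)=O)cc2)CC1` has not been measured yet. It differs from compound 2 in a single place: furan-2-yl in place of 4-chlorophenyl on a carbonyl carbon. Compound 1 already carries the furan-2-yl amide, yet its other difference from compound 3 leaves the effect of this swap on its own unknown.

Without a matched pair, the expected step from compound 2 to compound 3 is estimated as a 1.6-fold higher number from compound 2 to compound 3 (0.20 log units; within the scatter), a modest move toward a weaker inhibitor, since compound 1 with the same furan-2-yl group gives 15100 nM. Compound 3 is therefore expected to give about 9000 nM in this assay, within a range of 3500 nM to 25000 nM.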

Compound 3, half-maximal inhibitory concentration: 37400 nM
Beside the measured number, compound 3's estimate is 4.2-fold (0.62 log units) below it; measured number above the stated range.
By their numbers in this assay, from the lowest: compound 2; then compound 1; then compound 3.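

In this assay, the new pair isolates the group on the amide carbonyl: furan-2-yl in place of 4-chlorophenyl on a carbonyl carbon gives a 6.6-fold higher number from compound 2 to compound 3 (0.82 log units; beyond the scatter), so the number responds clearly to this one swap, and 4-chlorophenyl is the better of these two groups on the amide. The compound also gives a second single change, amino in place of ethoxy on a carbonyl carbon, which gives a 2.5-fold higher number from compound 1 to compound 3 (0.39 log units; beyond the scatter), so with furan-2-yl on the amide, the ethoxy group gives the lower number of the two. Nothing measured here explains either step.

As far as these compounds go, both steps rest on a single pair each, so it remains open whether amino and ethoxy would rank the same way with 4-chlorophenyl on the amide. From the compounds shown here alone, it is also open whether the lower number of compound 2 depends on the chlorine or on the six-membered ring itself, a question that a plain phenyl group, or a 4-methoxyphenyl group, on the same carbonyl carbon could help to separate.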